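Pyridin-3-yl to pyridin-4-yl swap: cytotoxicity notes

The source may hold more compounds than are shown below. What is called first, only, known or untested is meant among the compounds shown, and "the series" means these compounds.

Compound 1 `CN1C/C(=C\c2ccc(C(F)(F)F)cc2)C(=O)/C(=C/c2cccnc2)C1` and compound 2 `CN1C/C(=C\c2ccncc2)C(=O)/C(=C/c2ccc(C(F)(F)F)cc2)C1` share one core; in a functional assay on HepG2 cells (Homo sapiens) for cytotoxicity, read by MTT assay, with a stated time of 24 h (a higher number here means a weaker inhibitor, a lower number a stronger inhibitor), compound 1 gives 4790 nM and compound 2 gives 8200 nM. The change between them is pyridin-4-yl in place of pyridin-3-yl on a double-bonded chain carbon bound to a double-bonded ring carbon and gives a 1.7-fold higher number from compound 1 to compound 2 (0.23 log units; within the scatter). Compound 3 `O=C1/C(=C/c2cccnc2)CNC/C1=C\c1ccccc1C(F)(F)F` carries a different core; how the two cores differ is not broken down here. In this assay compound 3 gives 5020 nM, which with compound 1 lies within the scatter, as does its gap to compound 2.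

Compound 4 `O=C1/C(=C/c2ccncc2)CNC/C1=C\c1ccccc1C(F)(F)F` is not yet measured. It differs from compound 3 by pyridin-4-yl in place of pyridin-3-yl on a double-bonded chain carbon bound to a double-bonded ring carbon, the same change as from compound 1 to compound 2, at the same place.

For compound 4 a step of a 1.4-fold higher number from compound 3 to compound 4 (0.14 log units; within the scatter) in this assay is expected, set beside a 1.7-fold higher number from compound 1 to compound 2 (0.23 log units; within the scatter); it rests on that one earlier step only, made on another core, so the estimate is given a wide range. Compound 4 is thus expected to give 7000 nM in this assay, between 3500 nM and 14000 nM.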

Compound 4, half-maximal inhibitory concentration: 6130 nM
Beside the measured number, compound 4's estimate is 1.1-fold (0.06 log units) above it; the range from low to high includes it.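

In this assay putting pyridin-4-yl in place of pyridin-3-yl gives a 1.2-fold higher number from compound 3 to compound 4 (0.09 log units; within the scatter), and the swap reads the same on both cores: the same change on two cores in this assay, a 1.7-fold higher number (0.23 log units; within the scatter) from compound 1 to compound 2 and a 1.2-fold higher number (0.09 log units; within the scatter) from compound 3 to compound 4, 1.4-fold (0.15 log units) apart, within the scatter of two such steps. Both steps lie within the scatter, so the agreement amounts only to this: on neither core can the step be told apart from repeated measurement. This does not show that the swap has any real effect on cytotoxicity on either core, and two pairs on two cores say nothing about other cores in the series or about any other assay.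

Still open, going by these compounds, is whether a different group on the same double-bonded chain carbon, such as a carboxylic acid or an amine in place of the pyridinyl ring, would move the number beyond the scatter. No pair shown isolates the difference between the two cores, so what that difference contributes in this series remains unassigned.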